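A hydroxy chain gives way to an ether chain

The source may report more compounds than this note shows. Statements on the series, on what has been measured and on what is new or still open speak of the compounds shown alone.

- compound 1 `COC(=O)CCCCCCCCCCCCCC/C=C1\CC(CO)(COC(=O)C(C)(C)C)OC1=O`: > 10 ug/mL
- compound 2 `CCCCCCCCC(O)CCCCCC/C=C1\CC(CO)(COC(=O)C(C)(C)C)OC1=O`: > 10 ug/mL
- compound 3 `CCCCCOCCCCCCC/C=C1\CC(CO)(COC(=O)C(C)(C)C)OC1=O`: not yet measured

In a functional assay on Hs-578T cells (Homo sapiens) for antiproliferative activity (a higher number here means a weaker inhibitor of growth, a lower number a stronger inhibitor of growth), compound 1 gives > 10 ug/mL, which is a limit and not a number. Compound 2 gives > 10 ug/mL, again a limit. So compound 2 stands on (the limit of > 10 ug/mL in this assay, at which 2 of the 2 values shown sit).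

Compound 3 has (pentyloxy)methyl in place of 1-hydroxynonyl on a saturated chain carbon, six bonds along the chain from a double-bonded chain carbon. For the measured compounds named here, no measured step exists to guide the expectation, so none beyond the scatter is expected in this assay. The expected change is a step that the limit leaves unreadable from compound 2 to compound 3. Compound 3 is estimated at 12 ug/mL, with an expected range of 5 ug/mL to 30 ug/mL.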

Compound 3, concentration for 50% growth inhibition: 3 ug/mL
Compound 3: the middle estimate sits 4.0-fold (0.60 log units) above what was measured; the measured number lies below the stated range.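

This chain position turns out to tolerate a change that gives a readable number in this assay: (pentyloxy)methyl in place of 1-hydroxynonyl gives an at least 3.3-fold lower number from compound 2 to compound 3 (0.52 log units; beyond the scatter). Likewise, pentyloxy in place of 7-(methoxycarbonyl)heptyl gives an at least 3.3-fold lower number from compound 1 to compound 3 (0.52 log units; beyond the scatter). The full size of both steps cannot be read because each starts from a limit: the limit of > 10 ug/mL in this assay, at which 2 of the 3 values shown sit.

The first swap removes the hydroxy group and shortens the side branch together, so the compounds shown do not separate those two changes. From the compounds shown here alone, whether a longer ether chain or an amine at this place would do better remains open.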